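Swapping a Phenoxymethyl for a Phenoxy on the Tail

The compounds below may be only part of what the source reports. "The series", "measured", "known", "first", "only" and "open" are said of these compounds alone.

Among the measured compounds shown here, compound 2, `COC(=O)c1ccc(-c2cnc(C(=O)CCc3ccc(COc4ccccc4)cc3)o2)nc1`, is one of two compounds measured in an assay for inhibition of Fatty-acid amide hydrolase 1 (Rattus norvegicus); a higher number here means a weaker inhibitor, a lower number a stronger inhibitor. In this assay compound 2 gives 3.5 nM. Compound 1, `COC(=O)c1cnc(C(=O)CCc2ccc(Oc3ccccc3)cc2)o1`, has a smaller core and gives 1.7 nM in this assay, so compound 2 stands with the higher of the two numbers, a gap that lies beyond the usual scatter. Compound 3, `COC(=O)c1ccc(-c2cnc(C(=O)CCc3ccc(Oc4ccccc4)cc3)o2)nc1`, has not yet been measured. It keeps the core of compound 2 and changes only the tail: phenoxy in place of phenoxymethyl on an aromatic carbon. For the measured compounds named here, no measured pair differs in this one place, so the step cannot be read from the data directly. The group that enters is the tail of compound 1, whose value of 1.7 nM is the lower of the two. Compound 3 is therefore expected to show a slightly lower number, with a step of a 1.6-fold lower number from compound 2 to compound 3 (0.20 log units; within the scatter) that may well sit within the scatter. Compound 3 is estimated at 2.2 nM, in a range from 0.8 nM to 6 nM.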

Compound 3, inhibition constant: 54 nM
The estimate for compound 3 lay 25-fold (1.39 log units) below the measured number, and the stated range ends below it.
By their numbers in this assay, from the lowest: compound 1; then compound 2; then compound 3.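

On the core of compound 2, phenoxy in place of phenoxymethyl gives a 15-fold higher number from compound 2 to compound 3 (1.19 log units; beyond the scatter) in this assay, so this spot on the tail is highly sensitive, even though both groups carry the same aromatic ring and an oxygen. With the phenoxy tail held fixed, 5-(methoxycarbonyl)pyridin-2-yl in place of methoxycarbonyl gives a 32-fold higher number from compound 1 to compound 3 (1.50 log units; beyond the scatter), so a phenoxy tail does not by itself ensure a low number and its worth cannot be carried over from one core to another. Nothing measured here gives a reason for either step.

Going by these compounds, it remains open how phenoxymethyl would behave on the core of compound 1, which would show whether the tail and core effects depend on each other. Also open, on these data alone, is whether a longer chain, such as phenoxyethyl, would extend the trend from phenoxy to phenoxymethyl on the core of compound 2.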